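The compounds below may be only part of what the source reports. "The series", "measured", "known", "first", "only" and "open" are said of these compounds alone.

Measured compounds:
- compound 1, `O=C(CN(c1ncnc2c1ncn2C1CCCCO1)C1CC1)NCC(=O)OCc1ccccc1`: 17.2%
- compound 2, `O=C(O)CC[C@H](NC(=O)CN(c1nc(Cl)nc2[nH]cnc12)C1CC1)C(=O)O`: 30.1%

In a functional assay on the whole organism (Tail, strain ICR) with Mus musculus as the target, in the tail flick test, with a stated time of 120 min, at a dose of 25 umol/kg by the oral route (a higher number here means a stronger effect of the compound at the dose given, a lower number a weaker effect), compound 1 gives 17.2%, the lower of the two numbers; compound 2 gives 30.1%, a gap beyond the scatter. Compound 3, `CSCC[C@H](NC(=O)CN(c1ncnc2c1ncn2C1CCCCO1)C1CC1)C(=O)OCc1ccccc1`, is not yet measured. It differs from compound 1 by 2-(methylsulfanyl)ethyl in place of hydrogen on a saturated chain carbon bound to an amide-type nitrogen and a carbonyl carbon. Going by the values given here, no step between measured compounds covers this change, so only a guess is possible. The expectation is a small step in this assay, upward if any, likely within the scatter, a number 6.8 percentage points higher from compound 1 to compound 3 (within the scatter). Compound 3 is expected to give about 24%, with a range from 8% to 45%.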

Compound 3, a percentage reported as activity, at one dose (the size of the read-out at that dose, not a potency): 28.7%
Compound 3: middle estimate off by 4.7 percentage points, on the low side, within the range that was stated.
By their numbers in this assay, from the lowest: compound 1; then compounds 3 and 2 (each within the scatter of the next).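

In this assay, 2-(methylsulfanyl)ethyl in place of hydrogen on a saturated chain carbon bound to an amide-type nitrogen and a carbonyl carbon gives a number 11.5 percentage points higher from compound 1 to compound 3 (beyond the scatter), so this carbon carries a substituent with a gain rather than a loss at this dose. No data at hand explain this step.

From the compounds shown here alone, whether the sulfur matters or the chain alone suffices remains open, since a plain butyl chain at this carbon would separate the two. An amine or a hydroxyl at the end of the chain is equally untested here.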